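The source may report more compounds than this note shows. Statements on the series, on what has been measured and on what is new or still open speak of the compounds shown alone.

Measured in an ADME assay on MDCKII-LE cells (Canis lupus familiaris) for permeability, read by transwell migration, in the apical to basolateral direction; a lower number here means that the compound crosses the layer more slowly, a higher number that the compound crosses the layer faster:
- compound 1 `NC(=O)[C@@H](CCC(F)(F)F)N(C[C@H]1CCCCO1)S(=O)(=O)c1ccc(Cl)cc1`: 13.4 10^-6 cm/s
- compound 2 `NC(=O)[C@@H](CCC(F)(F)F)N(C[C@@H]1COCCO1)S(=O)(=O)c1ccc(Cl)cc1`: 27.3 10^-6 cm/s

Compound 1 holds the lower of the two numbers. Compound 3 `NC(=O)[C@@H](CCC(F)(F)F)N(C[C@@H]1CCOC1)S(=O)(=O)c1ccc(Cl)cc1` is unmeasured and differs from it as follows: oxolan-3-yl in place of oxan-2-yl on a saturated chain carbon bound to a sulfonamide nitrogen. Among the measured compounds shown here, the only measured step at this place is a 2.0-fold higher number from compound 1 to compound 2 (0.31 log units; beyond the scatter), and it is a modest one. It swaps in a different ring, so it is only a loose guide. A small rise in this assay is expected, probably not beyond the scatter. The estimated value for compound 3 is 18 10^-6 cm/s, with an expected range of 9 10^-6 cm/s to 32 10^-6 cm/s. The expected step is a 1.3-fold higher number from compound 1 to compound 3 (0.13 log units; within the scatter).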

Compound 3, apparent permeability: 20.5 10^-6 cm/s
For compound 3 the middle estimate is 1.1-fold (0.06 log units) below the measured one; low and high end bracket the measured number.
By their numbers in this assay, from the lowest: compounds 1, 3 and 2 (each within the scatter of the next, the first and the last beyond it).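

In this assay, oxolan-3-yl on a saturated chain carbon bound to a sulfonamide nitrogen cannot be separated from either six-membered ring: a 1.5-fold higher number from compound 1 to compound 3 (0.18 log units; within the scatter), and a 1.3-fold lower number from compound 2 to compound 3 (0.12 log units; within the scatter). Ring size and attachment point therefore change together here without a step beyond the scatter, while only compound 1 and compound 2 remain apart. No measurement available here explains these numbers.

Every ring shown contains oxygen, so the compounds leave open whether a cyclohexyl ring or a piperidine amine would stay within this range. Going by these compounds, the opposite stereocentre of the oxolan-3-yl group is also open.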